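Triazole series: methoxy to fluoro on the aryl ring

This account rests on a few compounds, and the source may have more. Where it says the series, first, only, none or still open, it means among the compounds named here.

Compound 2 `CCC[C@H](CCn1cncn1)c1ccc(OC)cc1` and compound 3 `CCCC[C@H](CCn1cncn1)c1ccc(OC)cc1` share a core that differs by methyl in place of hydrogen on a saturated chain carbon, four bonds along the chain from an aromatic carbon. In an ADME assay on HEp-2 cells (Homo sapiens) for cytotoxicity, read by MTT assay, with a stated time of 3 days (a higher number here means that more compound is tolerated, a lower number that less compound is tolerated), compound 2 gives 59.6 ug/mL, and compound 3 gives 34.5 ug/mL, a step of a 1.7-fold lower number from compound 2 to compound 3 (0.24 log units; within the scatter). Compound 1 `CCC[C@H](CCn1cncn1)c1ccc(F)cc1` arises from compound 2 by fluoro in place of methoxy on an aromatic carbon; in this assay compound 1 gives 39.3 ug/mL, a step of a 1.5-fold lower number from compound 2 to compound 1 (0.18 log units; within the scatter). Compound 3 holds the lowest of the three numbers, yet its gap to compound 1 and to compound 2 lies within the scatter, so no order among the three can be read from these values.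

Compound 4 `CCCC[C@H](CCn1cncn1)c1ccc(F)cc1` is not yet measured. It arises from compound 3 by fluoro in place of methoxy on an aromatic carbon, the same change that leads from compound 2 to compound 1, at the same place on the ring. For the measured compounds named here, that earlier step, a 1.5-fold lower number from compound 2 to compound 1 (0.18 log units; within the scatter), stayed within the scatter, which is the only guide available for the new step. A step of similar size is expected in this assay, namely a 1.3-fold lower number from compound 3 to compound 4 (0.12 log units; within the scatter), because the earlier step of a 1.5-fold lower number from compound 2 to compound 1 (0.18 log units; within the scatter) was small and the base value of compound 3 at 34.5 ug/mL is the starting point. For compound 4 the estimate in this assay is 26 ug/mL, with a range from 13 ug/mL to 50 ug/mL.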

Compound 4, half-maximal cytotoxic concentration: 38.5 ug/mL
The estimate for compound 4 lay 1.5-fold (0.17 log units) below the measured number, within the range that was stated.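

In this assay, fluoro in place of methoxy on the second core gives a 1.1-fold higher number from compound 3 to compound 4 (0.05 log units; within the scatter), and the two instances of this change cannot be told apart: the same change on two cores in this assay, a 1.5-fold lower number (0.18 log units; within the scatter) from compound 2 to compound 1 and a 1.1-fold higher number (0.05 log units; within the scatter) from compound 3 to compound 4, 1.7-fold (0.23 log units) apart, within the scatter of two such steps

Methyl in place of hydrogen on the saturated chain, read on the fluoro compounds, gives a 1.0-fold lower number from compound 1 to compound 4 (0.01 log units; within the scatter), and this change also agrees with its earlier instance: the same change on two cores in this assay, a 1.7-fold lower number (0.24 log units; within the scatter) from compound 2 to compound 3 and a 1.0-fold lower number (0.01 log units; within the scatter) from compound 1 to compound 4, 1.7-fold (0.23 log units) apart, within the scatter of two such steps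

None of the four steps among compound 1, compound 2, compound 3 and compound 4 stands clear of the scatter, so the agreement is only among small steps; it gives no direction for either change and does not show that a step of real size would carry from one core to another.

The compounds shown leave open whether a ring group other than fluoro or methoxy, such as chloro, trifluoromethyl or an amine, would give a number that separates from these four in this assay. On these data alone, a longer chain, or a carboxylic acid on the chain, also remains open, as does the behaviour of all four compounds in any other test.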